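Trading the thioester carbonyl for a plain thioether

The source may report more compounds than this note shows. Statements on the series, on what has been measured and on what is new or still open speak of the compounds shown alone.

For the measured compounds named here, compound 2 `CSC(=O)CCCCc1cnc(C(=O)CCCCCCc2ccccc2)o1` gives 1.5 nM in an assay for inhibition of Fatty-acid amide hydrolase 1 (Rattus norvegicus), using a Dixon plot, with a stated time of 6 h (on this read-out lower numbers stand for stronger inhibition and higher numbers for weaker inhibition), the lowest of the three numbers so far. Compound 1 `N#C/C=C/c1ccc(-c2cnc(C(=O)CCCCCCc3ccccc3)o2)nc1` gives 2.7 nM in this assay, within the scatter of compound 2, while compound 3 `N#CCCCCCc1cnc(C(=O)CCCCCCc2ccccc2)o1` gives 4 nM. Compound 4 `CSCCCCCc1cnc(C(=O)CCCCCCc2ccccc2)o1` has not yet been measured; it differs from compound 2 by (methylsulfanyl)methyl in place of (methylsulfanyl)carbonyl on a saturated chain carbon, four bonds along the chain from an aromatic carbon. Going by the values given here, one measured step bears on this change: a 2.7-fold higher number from compound 2 to compound 3 (0.43 log units; beyond the scatter), where the same group was exchanged at the same place. The present change is therefore expected to give a step of similar size and direction, a 2.7-fold higher number from compound 2 to compound 4 (0.43 log units; beyond the scatter), a modest rise in this assay. Compound 4 is estimated at 4 nM, within a range from 1.5 nM to 12 nM.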

Compound 4, inhibition constant: 6.1 nM
Compound 4: the middle estimate sits 1.5-fold (0.18 log units) below what was measured; the range from low to high includes it.
By their numbers in this assay, from the lowest: compounds 2, 1, 3 and 4 (each within the scatter of the next, the first and the last beyond it).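

Removing the carbonyl from the thioester, so that 4-(methylsulfanyl)butyl stands in place of 3-((methylsulfanyl)carbonyl)propyl, gives a 4.1-fold higher number from compound 2 to compound 4 (0.61 log units; beyond the scatter) in this assay, so this position responds even when the sulfur stays. Exchanging the nitrile for methylsulfanyl gives a 1.5-fold higher number from compound 3 to compound 4 (0.18 log units; within the scatter), which does not separate these two chain ends. Nothing shown explains either step.

On these data alone, whether a carboxylic acid or a methyl ester at this chain end would match the thioester remains open. So does whether a longer chain carrying the thioester would hold its value.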